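The source may report more compounds than this note shows. Statements on the series, on what has been measured and on what is new or still open speak of the compounds shown alone.

Compound 1 `Cc1ncnc2[nH]cc(Sc3cccs3)c12`; compound 2 `COc1ncnc2[nH]cc(Sc3cccs3)c12`; compound 3 `CN(C)c1ncnc2[nH]cc(Sc3cccs3)c12`.

In a functional assay on CCRF-CEM cells (Homo sapiens), read by MTT assay, with a stated time of 3 days (a higher number here means a weaker inhibitor, a lower number a stronger inhibitor), compound 1 gives > 50000 nM, which is a limit of the assay and not a number. Compound 2 gives 18200 nM in this assay, and compound 3 gives 14600 nM. Compound 4 `Nc1ncnc2[nH]cc(Sc3cccs3)c12` differs from compound 1 by amino in place of methyl on an aromatic carbon. Two measured steps at the same place bear on this change: an at least 2.7-fold lower number from compound 1 to compound 2 (0.43 log units; beyond the scatter) and an at least 3.4-fold lower number from compound 1 to compound 3 (0.53 log units; beyond the scatter), while between those two replacements a 1.2-fold lower number from compound 2 to compound 3 (0.10 log units; within the scatter). A lowering of similar size is therefore expected in this assay when amino replaces methyl. Compound 4 is expected to give about 12000 nM, within a range from 3000 nM to 50000 nM, which corresponds to an expected step of an at least 4.1-fold lower number from compound 1 to compound 4 (0.61 log units; beyond the scatter).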

Compound 4, half-maximal inhibitory concentration: 16700 nM
Beside the measured number, compound 4's estimate is 1.4-fold (0.14 log units) below it; the range from low to high includes it.
By their numbers in this assay, from the lowest: compounds 3, 4 and 2 (each within the scatter of the next). At a limit, above all of these: compound 1.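

In this assay, amino joins methoxy and dimethylamino in lowering the number relative to methyl, with an at least 2.9-fold lower number from compound 1 to compound 4 (0.47 log units; beyond the scatter). The three replacements cannot be told apart, with a 1.1-fold higher number from compound 3 to compound 4 (0.06 log units; within the scatter) and a 1.1-fold lower number from compound 2 to compound 4 (0.04 log units; within the scatter), so the free amino group gives no separation from its methylated counterpart, dimethylamino. The step from compound 1 rests on a limit and gives only a bound: the limit of > 50000 nM in this assay, at which 1 of the 4 values shown sits.

As far as these compounds go, whether chlorine, a cyclic amine such as morpholine or a longer chain at this position would separate from these three remains open.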